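N-Methylation step in the benzisoxazole-free core sulfonamide series

The compounds below may be only part of what the source reports. "The series", "measured", "known", "first", "only" and "open" are said of these compounds alone.

Measured so far:
compound 1 `CNS(=O)(=O)Cc1noc2ccccc12` gives 23 mg/kg
compound 2 `CNS(=O)(=O)Cc1noc2ccc(F)cc12` gives 35 mg/kg
compound 3 `NS(=O)(=O)Cc1noc2ccc(Br)cc12` gives 14 mg/kg

The read-out throughout is a functional assay on the whole organism (strain STD-dd) with Mus musculus as the target, in the maximal electroshock model, with a stated time of 2 h; a lower number here means that less compound is needed, a higher number that more compound is needed for the effect. Compound 3 holds the lowest number of the three; compound 1 sits nearest to it, within the scatter, while compound 2 sits furthest away, beyond the scatter. Going by the values given here, the one single-point step that has been measured, a 1.5-fold higher number from compound 1 to compound 2 (0.18 log units; within the scatter), concerns fluoro in place of hydrogen on an aromatic carbon and lies within the scatter.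

The next compound, compound 4 `CNS(=O)(=O)Cc1noc2ccc(Br)cc12`, differs from compound 3 by methyl in place of hydrogen on a sulfonamide nitrogen. Among the compounds with values here, no measured step bears on this change: compounds 1 and 3 differ in two places at once, so their two values show only that the pair sit close together, and compound 2 differs from compound 3 in the same two places plus the halogen. Within the data shown here, the only single change measured is on the aromatic ring and says nothing about the sulfonamide nitrogen.

With nothing to lean on, the expectation for compound 4 is a step of a 1.3-fold higher number from compound 3 to compound 4 (0.11 log units; within the scatter), no larger than the scatter, in either direction. Compound 4 is therefore estimated at 18 mg/kg, with a range from 9 mg/kg to 36 mg/kg.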

Compound 4, dose for half-maximal effect: 15 mg/kg
Compound 4: the middle estimate sits 1.2-fold (0.08 log units) above what was measured; the range from low to high includes it.
By their numbers in this assay, from the lowest: compounds 3, 4, 1 and 2 (each within the scatter of the next, the first and the last beyond it).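

In this assay, going by these compounds alone, the sulfonamide nitrogen accepts methyl in place of hydrogen on the bromo core without a step beyond the scatter (a 1.1-fold higher number from compound 3 to compound 4 (0.03 log units; within the scatter)), the first direct reading at this position, though it rests on this single pair. Holding the methylsulfamoyl group fixed also gives the first reading of bromo on the aromatic carbon: bromo in place of fluoro gives a step beyond the scatter (a 2.3-fold lower number from compound 2 to compound 4 (0.37 log units; beyond the scatter)), whereas bromo in place of hydrogen stays within it (a 1.5-fold lower number from compound 1 to compound 4 (0.19 log units; within the scatter)). No supporting data are available to explain the size of any of these steps.

Whether amino to methylamino reads the same way on the fluoro core or on the core of compound 1 remains open, as no such pair is among the compounds shown. Also open, going by these compounds, is how a longer chain such as ethyl would read on the sulfonamide nitrogen, and how chloro or methoxy would read in place of bromo on the aromatic carbon.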